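The source may report more compounds than this note shows. Statements on the series, on what has been measured and on what is new or still open speak of the compounds shown alone.

Within the data shown here, the three compounds measured so far share one core and differ only in the amine on the aromatic carbon. Compound 1 `CN(c1ccc2cc(NC(=O)CCc3ccc(C(F)(F)F)cc3)ccc2n1)C1CCCCC1` gives 18 nM in an assay on isolated protein for displacement of a labelled ligand from melanin-concentrating hormone receptor 1 (Homo sapiens); a higher number here means a weaker inhibitor, a lower number a stronger inhibitor. Compound 2 `NC1CCN(c2ccc3cc(NC(=O)CCc4ccc(C(F)(F)F)cc4)ccc3n2)C1` gives 12 nM in that assay, and compound 3 `CN(c1ccc2cc(NC(=O)CCc3ccc(C(F)(F)F)cc3)ccc2n1)C1CCCC1` gives 2 nM. Compound 2 thus stands with the second highest number of the three: its nearest neighbour is compound 1, separated by a 1.5-fold lower number from compound 1 to compound 2 (0.18 log units; within the scatter), while compound 3, the strongest binder of the set, lies at a 6.0-fold lower number from compound 2 to compound 3 (0.78 log units; beyond the scatter). Compound 4 `Nc1ccc2cc(NC(=O)CCc3ccc(C(F)(F)F)cc3)ccc2n1` is the new structure, and its change from compound 2 is amino in place of 3-aminopyrrolidin-1-yl on an aromatic carbon. Among the measured compounds shown here, the steps that bear on it are those that alter the same amine: a 1.5-fold lower number from compound 1 to compound 2 (0.18 log units; within the scatter) and a 6.0-fold lower number from compound 2 to compound 3 (0.78 log units; beyond the scatter), both moving in the direction of stronger binding, and a 9.0-fold lower number from compound 1 to compound 3 (0.95 log units; beyond the scatter), also stronger. None of them removes the ring altogether, so the direction for compound 4 is uncertain. The author expects a step of a 10-fold higher number from compound 2 to compound 4 (1.00 log units; beyond the scatter) toward a weaker binder. Compound 4 is therefore estimated at 120 nM, within a range from 25 nM to 600 nM.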

Compound 4, half-maximal inhibitory concentration: 240 nM
Compound 4: middle estimate off by 2.0-fold (0.30 log units), on the low side, and the stated range covers the measured number.
By their numbers in this assay, from the lowest: compound 3; then compounds 2 and 1 (each within the scatter of the next); then compound 4.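

Replacing the ring-bearing amines with a bare amino group on the aromatic carbon next to the ring nitrogen weakens binding in this assay against each of them: there is a 20-fold higher number from compound 2 to compound 4 (1.30 log units; beyond the scatter) and a 13-fold higher number from compound 1 to compound 4 (1.12 log units; beyond the scatter) and also a 120-fold higher number from compound 3 to compound 4 (2.08 log units; beyond the scatter). Compound 4 is thus the weakest binder of the four, and all three of these steps are large, whereas the earlier exchanges among the larger amines stayed modest or within the scatter. At this position, the amino group alone does not match any of the three larger amines shown. The information given offers no explanation for this loss. On these data alone, what remains open is where between amino and the larger amines binding recovers, as a methylamino or dimethylamino group might show, and whether a piperidine or morpholine ring would fit the trend.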